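Shrinking the Hydroxylated Amide Ring: An Expected Solubility

The source may hold more compounds than are shown below. What is called first, only, known or untested is meant among the compounds shown, and "the series" means these compounds.

Compound 1, `Nc1ncc(-c2ccc(C(=O)N3CCC(O)CC3)cc2)nc1-c1ccc(C(F)(F)F)cc1`: 119000 nM
Compound 2, `Nc1ncc(-c2ccc(C(=O)N3CCC(O)C3)cc2)nc1-c1ccc(C(F)(F)F)cc1`: 129000 nM

In a physicochemical assay for solubility, read by HPLC, using the shake flask method, with a stated time of 2 h, at pH 2 (a lower number here means a less soluble compound, a higher number a more soluble compound), compound 1 gives 119000 nM and compound 2 gives 129000 nM. Compound 2 stands highest of the two numbers measured, but its step from compound 1 is a 1.1-fold higher number from compound 1 to compound 2 (0.04 log units; within the scatter), so the two compounds cannot be told apart on this assay.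

Compound 3, `Nc1ncc(-c2ccc(C(=O)N3CC(O)C3)cc2)nc1-c1ccc(C(F)(F)F)cc1`, has not been measured. Its change from compound 2 is 3-hydroxyazetidin-1-yl in place of 3-hydroxypyrrolidin-1-yl on a carbonyl carbon. For the measured compounds named here, the one step that bears on it is the earlier ring contraction, a 1.1-fold higher number from compound 1 to compound 2 (0.04 log units; within the scatter), which produced no movement beyond the scatter. A further contraction of the same hydroxylated ring on the carbonyl carbon is therefore expected to give a step of a 1.0-fold higher number from compound 2 to compound 3 (0.02 log units; within the scatter), with no direction beyond the scatter claimed. Compound 3 is estimated at 135000 nM, with a range from 70000 nM to 260000 nM.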

Compound 3, solubility: 110000 nM
Compound 3: the middle estimate sits 1.2-fold (0.09 log units) above what was measured; the range from low to high includes it.
By their numbers in this assay, from the lowest: compounds 3, 1 and 2 (each within the scatter of the next).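

With 3-hydroxyazetidin-1-yl on the carbonyl carbon, the ring can now be read at a third size, and the step from 3-hydroxypyrrolidin-1-yl is a 1.2-fold lower number from compound 2 to compound 3 (0.07 log units; within the scatter) in this assay. Set against 4-hydroxypiperidin-1-yl, the step is a 1.1-fold lower number from compound 1 to compound 3 (0.03 log units; within the scatter), so among these three hydroxylated rings, ring size does not separate compound 1, compound 2 and compound 3 in this measurement, which a single step could not show. No independent measurement here says why the three numbers stay together.

The compounds shown leave open whether a different group at this carbonyl carbon, such as a ring bearing an amine or a carboxylic acid in place of the hydroxyl, would move the number beyond the scatter. They also leave open whether the three compounds stay equally close in any other assay.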